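The source may report more compounds than this note shows. Statements on the series, on what has been measured and on what is new or still open speak of the compounds shown alone.

Compound 2, `CC#CC(CC(=O)O)c1ccc(OCc2ccc(C(=O)N3CCN(c4ccc(C)cc4)CC3)s2)cc1`, gives 211 nM in a functional assay on HEK293 cells for agonist activity at Free fatty acid receptor 1 (Homo sapiens), read by fluorescence and calcium flux (a higher number here means that more compound is needed for the effect, a lower number that less compound is needed), the lowest of the two numbers measured. Compound 1, `CC#CC(CC(=O)O)c1ccc(OCc2ccc(C(=O)N3CCN(C4CCCCC4)CC3)s2)cc1`, gives 820 nM in this assay, and the step of a 3.9-fold lower number from compound 1 to compound 2 (0.59 log units; beyond the scatter) is the only one measured. Compound 3, `CC#CC(CC(=O)O)c1ccc(OCc2ccc(C(=O)N3CCN(c4cccc(F)c4)CC3)s2)cc1`, differs from compound 2 by 3-fluorophenyl in place of 4-methylphenyl on an amine nitrogen in a ring. Among the compounds with values here, the one measured step concerns a change from cyclohexyl to an aromatic ring, not an exchange of one aromatic ring for another, so it does not bear directly on the step from compound 2 to compound 3. Both groups sit on the same amine nitrogen in a ring and match in size, so a step no larger than the scatter is expected, with the direction uncertain. Compound 3 is therefore expected to give about 260 nM in this assay, with a range from 100 nM to 700 nM. The expected step is a 1.2-fold higher number from compound 2 to compound 3 (0.09 log units; within the scatter).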

Compound 3, half-maximal effective concentration: 97 nM
The estimate for compound 3 lay 2.7-fold (0.43 log units) above the measured number, and the stated range ends above it.
By their numbers in this assay, from the lowest: compound 3; then compound 2; then compound 1.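

On the amine nitrogen in the ring, one aromatic ring cannot simply replace another without consequence in this assay: the exchange of 4-methylphenyl for 3-fluorophenyl gives a 2.2-fold lower number from compound 2 to compound 3 (0.34 log units; beyond the scatter), although both groups count the same heavy atoms and neither has a hydrogen-bond donor or acceptor. The earlier pair showed only a change from cyclohexyl to an aromatic ring; the choice of aromatic group now also proves to matter, and the widest step among these compounds is an 8.5-fold lower number from compound 1 to compound 3 (0.93 log units; beyond the scatter), with 3-fluorophenyl giving the lowest number. Nothing available here accounts for the step from 4-methylphenyl to 3-fluorophenyl.

That exchange alters both the group on the phenyl ring and its place, so the two contributions cannot be separated. On these data alone, the numbers for 3-methylphenyl and 4-fluorophenyl at this nitrogen would separate them, and these remain open.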